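A few compounds are considered here, and "the series" means these few. Any claim that something is new, unique, unknown or untested is made for them only; others in the source may bear on it.

Measured compounds:

Compound 1, `CC[C@@H](Nc1c(C#N)c(-c2ccc(-c3ccccc3NC)cc2)nc2cnccc12)C(N)=O`, in a physicochemical assay for lipophilicity, read by HPLC, at pH 7.5 (on this read-out higher numbers stand for higher lipophilicity and lower numbers for lower lipophilicity), gives 2.5.
Compound 2, `CC[C@@H](Nc1c(C#N)c(-c2ccc(-c3ccc(F)cc3)cc2)nc2cnccc12)C(N)=O`, in this assay gives 2.7.
Compound 3, `CC[C@@H](Nc1c(C#N)c(-c2ccc(-c3ccccc3Cl)cc2)nc2cnccc12)C(N)=O`, in this assay gives 2.9.

Compound 3 holds the highest of the three numbers. Its gap to compound 2 is small, a number 0.20 log units higher from compound 2 to compound 3 (within the scatter), and lies within the scatter; its gap to compound 1 is larger, a number 0.40 log units higher from compound 1 to compound 3 (beyond the scatter), and lies beyond it. Compound 4, `CC[C@@H](Nc1c(C#N)c(-c2ccc(-c3ccccc3C)cc2)nc2cnccc12)C(N)=O`, has not yet been measured in this assay. It differs from compound 3 in one place: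

methyl in place of chloro on an aromatic carbon

Among the compounds with values here, no measured pair shows methyl in place of chloro, so none of the three steps bears on it directly. Within the data shown here, the only step that touches the chloro group is a number 0.40 log units higher from compound 1 to compound 3 (beyond the scatter), which swapped a methylamino for it and gave a modest rise. The two steps that change the whole ring, a number 0.20 log units higher from compound 1 to compound 2 (within the scatter) and a number 0.20 log units higher from compound 2 to compound 3 (within the scatter), both stayed within the scatter. A step of the present size, one small group for another of the same size without donors or acceptors, is expected to stay within the scatter, if anything a touch lower. Compound 4 is therefore estimated at 2.8, between 2.5 and 3.1. That estimate means a step of a number 0.10 log units lower from compound 3 to compound 4 (within the scatter) is expected.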

Compound 4, distribution coefficient: 3
Compound 4: middle estimate off by 0.20 log units, on the low side, and the stated range covers the measured number.
By their numbers in this assay, from the lowest: compounds 1, 2, 3 and 4 (each within the scatter of the next, the first and the last beyond it).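

Methyl and chloro can now be compared directly at this place, on an aromatic carbon ortho to a large group: in this assay the exchange gives a number 0.10 log units higher from compound 3 to compound 4 (within the scatter) and so does not separate the two groups. The 2-methylphenyl and 4-fluorophenyl rings are not separated either, with a number 0.30 log units higher from compound 2 to compound 4 (within the scatter) as their step, while a number 0.50 log units higher from compound 1 to compound 4 (beyond the scatter) adds a second case beside a number 0.40 log units higher from compound 1 to compound 3 (beyond the scatter) in which a group taking the place of methylamino lies clearly apart from it, although compound 2 goes against any wider split, since a number 0.20 log units higher from compound 1 to compound 2 (within the scatter) shows no such separation. The data at hand offer no explanation for why methyl and chloro read alike here.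

Going by these compounds, this is a single pair on a single core, so it remains open whether methyl and chloro would also match at another place on the same ring or with a different group on the rest of the molecule. Also open, on these data alone, is how a methoxy group, a trifluoromethyl group, a dimethylamino group or a carboxylic acid would read at this place, and whether a longer chain such as propyl would stay close to methyl.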